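The source may hold more compounds than are shown below. What is called first, only, known or untested is meant among the compounds shown, and "the series" means these compounds.

Compounds measured so far:
- compound 1, `CCCCOC(=O)NS(=O)(=O)c1sc(CC(C)C)cc1-c1ccc(CN2C(=O)CN(C)C2=O)cc1`: 68.6 nM
- compound 2, `CCCCOC(=O)NS(=O)(=O)c1sc(CC(C)C)cc1-c1ccc(C(=O)c2cccs2)cc1`: 18.8 nM
- compound 3, `CCCCOC(=O)NS(=O)(=O)c1sc(CC(C)C)cc1-c1ccc(Cn2ccc(C(F)(F)F)n2)cc1`: 9.5 nM

In an assay on membranes from uterus for displacement of a labelled ligand from Angiotensin type II receptor (Sus scrofa), with a stated time of 1.5 h (a lower number here means a stronger inhibitor, a higher number a weaker inhibitor), compound 1 gives the highest of the three numbers. Its nearest neighbour is compound 2, which lies a 3.6-fold lower number from compound 1 to compound 2 (0.56 log units; beyond the scatter); the furthest is compound 3, which lies a 7.2-fold lower number from compound 1 to compound 3 (0.86 log units; beyond the scatter). Compound 2 and compound 3 sit close together, with a 2.0-fold lower number from compound 2 to compound 3 (0.30 log units; within the scatter).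

Compound 4, `CCCCOC(=O)NS(=O)(=O)c1sc(CC(C)C)cc1-c1ccc(C(=O)c2nccs2)cc1`, has not yet been measured in this assay. Against compound 1 it differs in one place:
(1,3-thiazol-2-yl)carbonyl in place of (3-methyl-2,5-dioxoimidazolidin-1-yl)methyl on an aromatic carbon

Among the compounds with values here, the step that bears most directly on this change is the one from compound 1 to compound 2, a 3.6-fold lower number from compound 1 to compound 2 (0.56 log units; beyond the scatter), since the group that enters there is a (thiophen-2-yl)carbonyl, also a five-membered aromatic ring joined through a carbonyl to the same aromatic carbon. The step from compound 1 to compound 3 points the same way. On that basis the number for compound 4 in this assay is expected to be lower than that of compound 1, by a modest step of about the size seen for compound 2: a 3.4-fold lower number from compound 1 to compound 4 (0.54 log units; beyond the scatter). The estimate for compound 4 is 20 nM, with a range from 7 nM to 60 nM.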

Compound 4, inhibition constant: 18.6 nM
Estimate against measurement, compound 4: 1.1-fold (0.03 log units) above; the measured number falls inside the stated range.
By their numbers in this assay, from the lowest: compounds 3, 4 and 2 (each within the scatter of the next); then compound 1.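

In this assay, within the data shown here, the pair of compound 2 and compound 4 is the first to hold the carbonyl fixed and vary only the ring on it: 1,3-thiazol-2-yl in place of thiophen-2-yl gives a 1.0-fold lower number from compound 2 to compound 4 (0.00 log units; within the scatter) and so the two rings cannot be told apart here. The second carbonyl-linked ring also stands clear of the (3-methyl-2,5-dioxoimidazolidin-1-yl)methyl group, with a 3.7-fold lower number from compound 1 to compound 4 (0.57 log units; beyond the scatter) as the step, while a 2.0-fold higher number from compound 3 to compound 4 (0.29 log units; within the scatter) leaves the (1,3-thiazol-2-yl)carbonyl group and the (3-(trifluoromethyl)-1H-pyrazol-1-yl)methyl group unseparated at this position para to a large group. Nothing at hand says why these groups behave as they do.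

From the compounds shown here alone, whether a phenyl or a pyridin-2-yl ring on the same carbonyl carbon would stay in this range in this assay remains open. Also open, going by these compounds, is what a methylene link in place of the carbonyl would do for the 1,3-thiazol-2-yl ring, and so how much of the result rests on the carbonyl itself.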